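The source may report more compounds than this note shows. Statements on the series, on what has been measured and on what is new or still open speak of the compounds shown alone.

Compound 3 `O=C(Nc1ccccc1Br)N[C@@H]1CCN(c2cccc(F)c2)C1` is one of three molecules that share a urea core and differ only in the aromatic ring attached to the ring nitrogen of the amine. In a functional assay for antagonist activity at transient receptor potential cation channel subfamily V member 1 (Rattus norvegicus), read by FLIPR (a higher number here means a more potent compound, by a factor of ten per unit of this negative logarithm, a lower number a less potent compound), compound 3 gives 7.8. That places it second of the three: compound 2 `Cc1ccc(N2CC[C@@H](NC(=O)Nc3ccccc3Br)C2)cc1F` gives 8.3 in this assay, and compound 1 `O=C(Nc1ccccc1Br)N[C@@H]1CCN(c2ccc(Br)cn2)C1` gives 7.2. The measured steps show the change of this aromatic ring matters: a number 1.10 log units higher from compound 1 to compound 2 (beyond the scatter) and a number 0.60 log units higher from compound 1 to compound 3 (beyond the scatter). The step of a number 0.50 log units lower from compound 2 to compound 3 (beyond the scatter) shows that removing a methyl from that ring costs potency.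

Compound 4 `Cc1cccc(N2CC[C@@H](NC(=O)Nc3ccccc3Br)C2)c1` is not yet measured. Its difference from compound 3 is methyl in place of fluoro on an aromatic carbon. Within the data shown here, the one measured step that bears on it, the loss of methyl in going from compound 2 to compound 3, was modest and downward, so putting a methyl back in, even at another position, is expected to hold or slightly raise the number. The expected step is therefore a number 0.20 log units higher from compound 3 to compound 4 (within the scatter), small and upward. Compound 4 is estimated at 8 in this assay, with a range from 7.4 to 8.6.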

Compound 4, negative logarithm of the antagonist equilibrium constant in the transient receptor potential cation channel subfamily V member 1 assay: 7.7
For compound 4 the middle estimate is 0.30 log units above the measured one; the measured number falls inside the stated range.
By their numbers in the transient receptor potential cation channel subfamily V member 1 assay, from the lowest: compound 1; then compounds 4 and 3 (each within the scatter of the next); then compound 2.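

In the transient receptor potential cation channel subfamily V member 1 assay, methyl and fluoro cannot be told apart at this position on the ring, a number 0.10 log units lower from compound 3 to compound 4 (within the scatter). The 3-methylphenyl group falls short of the 3-fluoro-4-methylphenyl group, a number 0.60 log units lower from compound 2 to compound 4 (beyond the scatter), yet it still improves on the 5-bromopyridin-2-yl group, a number 0.50 log units higher from compound 1 to compound 4 (beyond the scatter), so compound 4 sits in the same relation to the other two compounds as compound 3 does. In a physicochemical assay for solubility (a lower number here means a less soluble compound, a higher number a more soluble compound), compound 3 gives < 100 ug/mL, which is a limit and not a number. In the physicochemical assay compound 4 gives < 100 ug/mL, which is likewise a limit and not a number. In the physicochemical assay the step between the two compounds cannot be read, as both values are limits and not numbers: the limit of < 100 ug/mL in the physicochemical assay, at which 2 of the 2 values shown sit.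

Going by these compounds, whether a larger or quite different group at this position, such as a methoxy, a nitrile or an amine, would separate from methyl and fluoro stays open. Also open, on these data alone, is how compound 3 and compound 4 rank in the physicochemical assay.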